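Mirror image at the tetrahydrofuran carbon of compound 1

The source may report more compounds than this note shows. Statements on the series, on what has been measured and on what is new or still open speak of the compounds shown alone.

Measured compounds:
- compound 1, `Cc1c(Nc2nc(N)c3c(C#N)c(N4CCC[C@H]4C)n(C)c3n2)cnn1[C@@H]1CCOC1`: 80 nM
- compound 2, `Cc1nn(C2CCOC2)cc1Nc1nc(N)c2c(C#N)c(N3CCC[C@H]3C)n(C)c2n1`: 65 nM; 180 nM (2 entries)

In an assay on HEK293 cells for inhibition of Leucine-rich repeat serine/threonine-protein kinase 2 variant G2019S (Homo sapiens), with a stated time of 48 h (a lower number here means a stronger inhibitor, a higher number a weaker inhibitor), compound 1 gives 80 nM, and this is the only number shown for it in this assay. Compound 2 carries the same core with the methyl of the pyrazole in a different place and no configuration drawn at its ring carbon; its several entries, (the several entries of compound 2 in this assay, 65 nM; 180 nM (2 entries)), spread on both sides of the value of compound 1, so the two compounds cannot be set in order here.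

Compound 3, `Cc1c(Nc2nc(N)c3c(C#N)c(N4CCC[C@H]4C)n(C)c3n2)cnn1[C@H]1CCOC1`, has not yet been measured. Compared with compound 1 the difference is the two compounds have the same atoms and bonds and differ only in configuration as drawn: 1 of 2 stereo elements differ; a stereocentre at a saturated ring carbon is drawn R in compound 1 and S in compound 3. Among the compounds with values here, no measured pair in this set shows what such a change does. A step of modest size, toward weaker inhibition and possibly just beyond the scatter, is expected in this assay, a 2.0-fold higher number from compound 1 to compound 3 (0.30 log units; within the scatter). Compound 3 is therefore estimated at 160 nM, within 50 nM to 500 nM.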

Compound 3, half-maximal inhibitory concentration: 51 nM
The estimate for compound 3 lay 3.1-fold (0.50 log units) above the measured number, within the range that was stated.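

In this assay, the configuration at the saturated ring carbon now has a measured pair, and redrawing it from R to S gives a 1.6-fold lower number from compound 1 to compound 3 (0.20 log units; within the scatter). Within the data shown here, this is the first step in the set, and it can be assigned to that one stereocentre alone, for a single reason: the fact that compounds 1 and 3 differ only in the configuration as drawn. At this position the two configurations cannot be told apart in this assay, so the result gives no preference for either one.

What remains open is whether the ring at this position matters at all, as the tetrahydrofuran ring is the only group shown on this nitrogen of the pyrazole, and a piperidine or a plain methyl there could test this. Going by these compounds, the second stereo element is the same in compound 1 and compound 3, so its contribution also remains unknown.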